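The compounds below may be only part of what the source reports. "The series", "measured", "known", "first", "only" and "open" are said of these compounds alone.

In a functional assay on SK-MEL-2 cells (Homo sapiens) for inhibition, read by sulforhodamine B assay, with a stated time of 48 h (on this read-out higher numbers stand for weaker inhibition of growth and lower numbers for stronger inhibition of growth), compound 1 `O=C(Nc1cccc(-n2cc(-c3ccncc3)c(-c3ccc(Cl)c(O)c3)n2)c1)Nc1ccc(Cl)c(Cl)c1` gives 2640 nM, and compound 2 `COc1cc(-c2nn(-c3cccc(NC(=O)c4ccc(Cl)c(C(F)(F)F)c4)c3)cc2-c2ccncc2)ccc1Cl` gives 19700 nM. Compound 3 `COc1cc(-c2nn(-c3cccc(NC(=O)c4cccc(C(F)(F)F)c4)c3)cc2-c2ccncc2)ccc1Cl` reaches only the boundary of this assay, reported as > 50000 nM, which is a limit rather than a measured number. The step of an at least 2.5-fold higher number from compound 2 to compound 3 (0.40 log units; beyond the scatter), hydrogen in place of chloro on an aromatic carbon, therefore ends at that limit, and compound 3 stands at the weak end of the three values shown (the limit of > 50000 nM in this assay, at which 1 of the 3 values shown sits).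

Compound 4 `COc1cc(-c2nn(-c3cccc(NC(=O)c4ccccc4)c3)cc2-c2ccncc2)ccc1Cl` differs from compound 3 by hydrogen in place of trifluoromethyl on an aromatic carbon. Among the compounds with values here, no measured step removes a trifluoromethyl, so the closest guide is an at least 2.5-fold higher number from compound 2 to compound 3 (0.40 log units; beyond the scatter), where taking a chloro off the same benzoyl ring gave weaker inhibition. Removing the remaining trifluoromethyl is expected to go the same way or to stay within the scatter; the expected step for compound 4 is a step that the limit leaves unreadable from compound 3 to compound 4. Compound 4 is estimated at 60000 nM, with a range from 20000 nM to 200000 nM, most likely again only a limit.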

Compound 4, concentration for total growth inhibition: 4970 nM
Beside the measured number, compound 4's estimate is 12-fold (1.08 log units) above it; the whole stated range lies above it.
By their numbers in this assay, from the lowest: compounds 1 and 4 (each within the scatter of the next); then compound 2. At a limit, above all of these: compound 3.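

Taking the trifluoromethyl off this benzoyl ring does not repeat what taking the chloro off did. The direction reverses: the change gives an at least 10-fold lower number from compound 3 to compound 4 (1.00 log units; beyond the scatter). The value of compound 3 is a limit: the limit of > 50000 nM in this assay, at which 1 of the 4 values shown sits. The plain benzoyl ring also compares well with the 4-chloro-3-(trifluoromethyl)phenyl version, with a 4.0-fold lower number from compound 2 to compound 4 (0.60 log units; beyond the scatter), so among compounds 2, 3 and 4, removing groups from this ring does not act in one direction, and compound 3, with trifluoromethyl alone, goes against any simple trend.

These compounds do not tell why the two removals run in opposite directions. On these data alone, it also remains open how this ring would behave with chloro alone, or with an amine or a carboxylic acid at the same place.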